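Furan for pyridine on a chlorophenyl pyridine inhibitor

A few compounds are considered here, and "the series" means these few. Any claim that something is new, unique, unknown or untested is made for them only; others in the source may bear on it.

The study measures two compounds in an assay on isolated protein for inhibition of DNA topoisomerase 1 (Homo sapiens), with a stated time of 30 min, tested at 100 uM (a higher number here means a stronger effect of the compound at the concentration tested, a lower number a weaker effect), and leaves a third to be measured. Compound 1 `Oc1ccc(-c2cc(-c3ccco3)nc(-c3ccccc3Cl)c2)cc1` gives 3.9% in this assay. Compound 2 `Oc1cccc(-c2cc(-c3ccccn3)nc(-c3ccccc3Cl)c2)c1` gives 0% in this assay, the lower of the two numbers, though its gap to compound 1 is within the usual scatter, so neither can be called the weaker. Compound 3 `Oc1cccc(-c2cc(-c3ccco3)nc(-c3ccccc3Cl)c2)c1` is the unmeasured one; it differs from compound 2 in one place: furan-2-yl in place of pyridin-2-yl on an aromatic carbon. For the measured compounds named here, no step between two measured compounds is available to gauge this change. Both measured numbers sit close to the floor of the read-out, so the step from compound 2 to compound 3 is expected to be small in this assay, a number 3 percentage points higher from compound 2 to compound 3 (within the scatter), within the scatter and in no clear direction. Compound 3 is therefore expected to give about 3% in this assay, within a range from 0% to 15%.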

Compound 3, a percentage reported as inhibition, at one concentration (the size of the read-out at that concentration, not a potency): 0%
Estimate against measurement, compound 3: 3 percentage points above; low and high end bracket the measured number.
By their numbers in this assay, from the lowest: compounds 2, 3 and 1 (each within the scatter of the next).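

In this assay, furan-2-yl in place of pyridin-2-yl on this aromatic carbon gives no change at the digits printed from compound 2 to compound 3 (within the scatter) and so shows that, with a 3-hydroxyphenyl group on the shared core, exchanging the six-membered ring for the five-membered one leaves the read-out at its floor. With furan-2-yl held constant, 3-hydroxyphenyl in place of 4-hydroxyphenyl gives a number 3.9 percentage points lower from compound 1 to compound 3 (within the scatter) and so adds that these two hydroxyphenyl groups cannot be told apart in this read-out. Nothing available explains why the three compounds read alike.

The compounds shown leave open whether any group at this position would lift the read-out clear of its floor, for example an amine or a carboxylic acid in place of the furan-2-yl ring. They also leave open what a methoxy group in place of the chlorine on the 2-chlorophenyl group would do.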